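The compounds below may be only part of what the source reports. "The series", "measured", "known", "first", "only" and "open" are said of these compounds alone.

Among the measured compounds shown here, in an ADME assay on Jurkat cells (Homo sapiens) for cytotoxicity, read by MTT assay, with a stated time of 72 h (a lower number here means a stronger inhibitor, a higher number a weaker inhibitor), compound 1 `COC(=O)c1cnc(Oc2ccc3c(c2)B(O)OC3)cn1` gives 7590 nM, the only true number among the measured compounds. Compound 2 `CN(C)C(=O)c1cnc(Oc2ccc3c(c2)B(O)OC3)cn1` reaches only a limit of the assay, > 100000 nM. Compound 3 `CC(C)OC(=O)c1cnc(Oc2ccc3c(c2)B(O)OC3)cn1` also stands at a limit, > 100000 nM. Compound 4 `CC(C)COC(=O)c1cnc(Oc2ccc3c(c2)B(O)OC3)cn1` differs from compound 1 by isopropyl in place of hydrogen on a saturated chain carbon bound to an oxygen next to a carbonyl group, which turns methoxycarbonyl into isobutoxycarbonyl. The closest measured change is an at least 13-fold higher number from compound 1 to compound 3 (1.11 log units; beyond the scatter), with isopropyl in place of methyl on an oxygen next to a carbonyl group. The other measured change at this carbonyl, an at least 13-fold higher number from compound 1 to compound 2 (1.11 log units; beyond the scatter), is also large and runs the same way. A large rise in this assay is therefore expected, shown as a 6.6-fold higher number from compound 1 to compound 4 (0.82 log units; beyond the scatter). Compound 4 is estimated at 50000 nM, within an expected range of 12000 nM to 100000 nM.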

Compound 4, half-maximal inhibitory concentration: 17600 nM
Beside the measured number, compound 4's estimate is 2.8-fold (0.45 log units) above it; low and high end bracket the measured number.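

In this assay, a larger group on this oxygen need not carry the number to the limit: isopropyl in place of hydrogen on the saturated chain carbon gives a 2.3-fold higher number from compound 1 to compound 4 (0.37 log units; beyond the scatter), a modest step. Isobutyl in place of isopropyl gives an at least 5.6-fold lower number from compound 3 to compound 4 (0.75 log units; beyond the scatter), and isobutoxy in place of dimethylamino gives an at least 5.6-fold lower number from compound 2 to compound 4 (0.75 log units; beyond the scatter), so the outcome depends on which group is present, not simply on whether methoxy is replaced. Both of these steps start from a limit and are bounds only: the limit of > 100000 nM in this assay, at which 2 of the 4 values shown sit.

As far as these compounds go, whether a longer chain such as hexyl would stay near compound 4 or reach the limit remains open. So does the effect of a carboxylic acid at this carbonyl.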